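The compounds below may be only part of what the source reports. "The series", "measured", "known", "first", "only" and "open" are said of these compounds alone.

Measured so far:
compound 1 `O=c1cc(-c2ccccc2)oc2cccc(OCCCCN3CCC(O)CC3)c12` — 58 nM
compound 2 `CN(C)CCCCCCCCOc1ccc2oc(-c3ccccc3)cc(=O)c2c1` — 227 nM

In an assay on isolated protein (Cavia porcellus) with Sigma non-opioid intracellular receptor 1 (Homo sapiens) as the target, read by radioligand binding (on this read-out lower numbers stand for stronger inhibition and higher numbers for weaker inhibition), compound 2 gives 227 nM, the higher of the two numbers; compound 1 gives 58 nM, a gap beyond the usual scatter. Compound 3 `O=c1cc(-c2ccccc2)oc2ccc(OCCCCCCN3CCCC(O)C3)cc12` has not been measured yet. It differs from compound 2 by 3-hydroxypiperidin-1-yl in place of 2-(dimethylamino)ethyl on a saturated chain carbon, six bonds along the chain from an oxygen on an aromatic ring. Compound 1 also carries a hydroxypiperidine on its chain, and its lower value suggests that this group is tolerated; the step from compound 2 to compound 3 is therefore expected to be a 2.3-fold lower number from compound 2 to compound 3 (0.36 log units; beyond the scatter), a modest gain beyond the scatter. Compound 3 is estimated at 100 nM, with a range from 30 nM to 300 nM.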

Compound 3, half-maximal inhibitory concentration: 86 nM
Compound 3: the middle estimate sits 1.2-fold (0.07 log units) above what was measured; measured number inside the range.
By their numbers in this assay, from the lowest: compounds 1 and 3 (each within the scatter of the next); then compound 2.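

In this assay the swap of 2-(dimethylamino)ethyl for 3-hydroxypiperidin-1-yl gives a 2.6-fold lower number from compound 2 to compound 3 (0.42 log units; beyond the scatter) and so counts as a modest gain. At this chain position, then, the open-chain dimethylamino end is not needed, and a six-membered ring carrying a hydroxyl is accepted. Whether the ring or the hydroxyl accounts for the gain remains open, since neither a plain piperidine nor a morpholine stands at this chain end among the compounds shown. No measurement at hand explains the step.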